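A few compounds are considered here, and "the series" means these few. Any claim that something is new, unique, unknown or untested is made for them only; others in the source may bear on it.

Measured compounds:
compound 1 `COC(=O)c1sc2cc(OC)ccc2c1C#Cc1ccccc1` with 42300 nM
compound 2 `COC(=O)c1sc2cc(OC)ccc2c1C#Cc1ccc(F)cc1` with 10100 nM
compound 3 `COC(=O)c1sc2ccccc2c1C#Cc1ccccc1` with 58900 nM

All numbers come from a functional assay on cells (CNS cell, Homo sapiens) for cytotoxicity, read by sulforhodamine B assay, with a stated time of 48 h; a higher number here means a weaker inhibitor of growth, a lower number a stronger inhibitor of growth. Compound 1 and compound 3 differ by hydrogen in place of methoxy on an aromatic carbon; in this assay this gives a 1.4-fold higher number from compound 1 to compound 3 (0.14 log units; within the scatter). Compound 1 and compound 2 differ by fluoro in place of hydrogen on an aromatic carbon, and the step is a 4.2-fold lower number from compound 1 to compound 2 (0.62 log units; beyond the scatter).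

Compound 4 `COC(=O)c1sc2ccccc2c1C#Cc1ccccc1F` has not been measured. It differs from compound 3 by fluoro in place of hydrogen on an aromatic carbon. This is the same kind of change as from compound 1 to compound 2, but the place is not the same: there it was para to a large group, here ortho to a large group. Because the earlier step of a 4.2-fold lower number from compound 1 to compound 2 (0.62 log units; beyond the scatter) was measured at a different place, a smaller step is expected here, estimated as a 2.0-fold lower number from compound 3 to compound 4 (0.29 log units; within the scatter). For compound 4 the value in this assay is estimated at 30000 nM, within 12000 nM to 80000 nM.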

Compound 4, concentration for 50% growth inhibition: 30200 nM
For compound 4 the middle estimate is 1.0-fold (0.00 log units) below the measured one, within the range that was stated.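

In this assay fluoro in place of hydrogen gives a 2.0-fold lower number from compound 3 to compound 4 (0.29 log units; within the scatter) and this step on its own lies within the scatter. The step on this core cannot be told apart from the earlier one: the same change on two cores in this assay, a 4.2-fold lower number (0.62 log units; beyond the scatter) from compound 1 to compound 2 and a 2.0-fold lower number (0.29 log units; within the scatter) from compound 3 to compound 4, 2.1-fold (0.33 log units) apart, within the scatter of two such steps. This agrees with the change carrying over from one core to the other but does not establish it, since each core offers a single pair and the fluoro stands ortho to a large group in compound 4 but at a different place in compound 2, leaving core and place unseparated.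

Open, on these data alone, is the step with fluoro at one and the same place on both cores. Also open, as far as these compounds go, is whether chloro or an amine on the phenyl, or a carboxylic acid in place of the methyl ester, would follow the same course.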